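Swapping the amide on compound 1 for a carbamate

The source may hold more compounds than are shown below. What is called first, only, known or untested is meant among the compounds shown, and "the series" means these compounds.

Compound 1 `Cc1cc(C(=O)NCc2ccccn2)nn1Cc1cc(Cl)ccc1OCc1ccccc1`: 3.6 L/kg
Compound 2 `Cc1cc(NC(=O)c2ccccc2)nn1Cc1cc(Cl)ccc1OCc1ccccc1`: 4.1 L/kg
Compound 3 `Cc1cc(NC(=O)C2CCCCC2)nn1Cc1cc(Cl)ccc1OCC(C)C`: 3.5 L/kg

All three were tested in an in vivo ADME assay on the whole organism for pharmacokinetics, with Rattus norvegicus as the target; on this read-out higher numbers stand for wider distribution into tissues and lower numbers for narrower distribution. On that read-out compound 1 gives 3.6 L/kg, a number that sits between those of compound 3, which gives 3.5 L/kg, and compound 2, which gives 4.1 L/kg; both gaps are within the usual scatter, so the three compounds cannot be told apart on this measure.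

Compound 4 `Cc1cc(NC(=O)OC(C)(C)C)nn1Cc1cc(Cl)ccc1OCc1ccccc1` is not yet measured. It differs from compound 1 in one place: (tert-butoxycarbonyl)amino in place of ((pyridin-2-yl)methyl)carbamoyl on an aromatic carbon. Within the data shown here, the only measured step that touches the same position is the one from compound 1 to compound 2, where a benzamido group took the place of the ((pyridin-2-yl)methyl)carbamoyl group; that gave a 1.1-fold higher number from compound 1 to compound 2 (0.06 log units; within the scatter). Among the measured compounds shown here, no measured pair shows what a (tert-butoxycarbonyl)amino group does in this assay, and the remaining compound 3 differs from compound 1 in more than one place, so it carries no clean step. For the measured compounds named here, with the one relevant step within the scatter, no shift beyond the scatter is expected for compound 4, meaning an estimated no change at the digits printed from compound 1 to compound 4 (within the scatter). Compound 4 is therefore expected to give about 3.6 L/kg in this assay, estimated to lie between 1.8 L/kg and 7.2 L/kg.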

Compound 4, volume of distribution at steady state: 8.6 L/kg
Beside the measured number, compound 4's estimate is 2.4-fold (0.38 log units) below it; measured number above the stated range.
By their numbers in this assay, from the lowest: compounds 3, 1 and 2 (each within the scatter of the next); then compound 4.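

In this assay, this position on the five-membered aromatic ring now shows that a single change can move the number beyond the scatter: (tert-butoxycarbonyl)amino in place of ((pyridin-2-yl)methyl)carbamoyl gives a 2.4-fold higher number from compound 1 to compound 4 (0.38 log units; beyond the scatter), whereas the earlier benzamido change gave only a 1.1-fold higher number from compound 1 to compound 2 (0.06 log units; within the scatter). The closer comparison keeps the amino-carbonyl link and changes only the group on the carbonyl carbon, with tert-butoxy in place of phenyl giving a 2.1-fold higher number from compound 2 to compound 4 (0.32 log units; beyond the scatter), so a change at that one point is enough to produce a step beyond the scatter. No measurement here accounts for why the number moves with this group.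

The compounds shown leave open whether the higher number goes with the oxygen of the tert-butoxy group or with its branched carbons, which a pivalamido group, with tert-butyl directly on the carbonyl carbon, or a methoxycarbonylamino group could help separate. They also leave open whether the same step would appear if the benzyl ether of compound 4 were replaced by the ether group carried by compound 3.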